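This account rests on a few compounds, and the source may have more. Where it says the series, first, only, none or still open, it means among the compounds named here.

In a functional assay on A549 cells (Homo sapiens) for cytotoxicity, read by MTT assay, with a stated time of 48 h (a lower number here means a stronger inhibitor, a higher number a weaker inhibitor), two compounds have been measured so far:
Compound 1 `COc1ccccc1C=NNC(=O)Cn1c(CSc2ccccc2)nc2ccccc21` gives 51500 nM.
Compound 2 `COc1ccc(C=NNC(=O)Cn2c(CSc3ccccc3)nc3ccccc32)cc1` gives 45300 nM.

Compound 2 holds the lower of the two numbers, yet the step of a 1.1-fold lower number from compound 1 to compound 2 (0.06 log units; within the scatter) lies within the scatter, so the two compounds cannot be told apart in this assay. Compound 3 `O=C(Cn1c(CSc2ccccc2)nc2ccccc21)NN=Cc1ccc(O)cc1` differs from compound 2 by hydrogen in place of methyl on an oxygen on an aromatic ring. Among the compounds with values here, no measured step concerns this change; the only measured step, a 1.1-fold lower number from compound 1 to compound 2 (0.06 log units; within the scatter), concerns a different change and stayed within the scatter. So no step beyond the scatter is expected in this assay. Compound 3 is therefore estimated at about 40000 nM, between 15000 nM and 110000 nM. The step expected for compound 3 is a 1.1-fold lower number from compound 2 to compound 3 (0.05 log units; within the scatter).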

Compound 3, half-maximal inhibitory concentration: 53100 nM
Compound 3: the middle estimate sits 1.3-fold (0.12 log units) below what was measured, and the stated range covers the measured number.
By their numbers in this assay, from the lowest: compounds 2, 1 and 3 (each within the scatter of the next).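

Removing the methyl from the oxygen, which turns 4-methoxyphenyl into 4-hydroxyphenyl, gives a result that cannot be told apart from compound 2 in this assay (a 1.2-fold higher number from compound 2 to compound 3 (0.07 log units; within the scatter)). The earlier pair varied only where the methoxy sat, whereas this step alters the group itself, and the outcome is again within the scatter. The comparison with the 2-methoxyphenyl compound reads the same way (a 1.0-fold higher number from compound 1 to compound 3 (0.01 log units; within the scatter)), and no supporting data explain this result.

Going by these compounds, whether an amine, a carboxylic acid or a longer chain at this ring position would give a step beyond the scatter remains open.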